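Working notes on compounds 1 to 4

This account rests on a few compounds, and the source may have more. Where it says the series, first, only, none or still open, it means among the compounds named here.

Values so far in a functional assay on HCT-116 cells (Homo sapiens) for cytotoxicity, read by MTT assay, with a stated time of 72 h; a higher number here means a weaker inhibitor, a lower number a stronger inhibitor:
compound 1 `O=S(=O)(c1ccccc1)c1nc2ccccc2nc1Nc1ccccc1` gives 1630 nM.
compound 2 `COc1ccc(S(=O)(=O)c2nc3ccccc3nc2Nc2ccccc2)cc1` gives 1260 nM.
compound 3 `COc1cc(Nc2nc3ccccc3nc2S(=O)(=O)c2ccc(Br)cc2)cc(OC)c1` gives > 50000 nM, which is a limit of the assay and not a number.

The step of a 1.3-fold lower number from compound 1 to compound 2 (0.11 log units; within the scatter) is the change (methoxy in place of hydrogen on an aromatic carbon). For compound 3 only the limit is known, (the limit of > 50000 nM in this assay, at which 1 of the 3 values shown sits). How the core of compound 3 differs from the core of compound 1 is not broken down here.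

Compound 4 `COc1cc(Nc2nc3ccccc3nc2S(=O)(=O)c2ccc(Br)cc2)cc(OC)c1OC` is not yet measured. It differs from compound 3 by methoxy in place of hydrogen on an aromatic carbon, the same kind of change as from compound 1 to compound 2, though here the entering methoxy stands ortho to two methoxy groups, where the earlier one was only para to a large group. Since the earlier step of a 1.3-fold lower number from compound 1 to compound 2 (0.11 log units; within the scatter) lay within the scatter, compound 4 is expected to stay close to compound 3, that is, a step that the limit leaves unreadable from compound 3 to compound 4 is expected. Compound 4 is therefore estimated at 60000 nM, most likely again reported only as a limit, with a plausible range of 20000 nM to 200000 nM.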

Compound 4, half-maximal inhibitory concentration: 13000 nM
Beside the measured number, compound 4's estimate is 4.6-fold (0.66 log units) above it; the whole stated range lies above it.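

In this assay the methoxy change does not carry over with one size from the core of compound 1 to the core of compound 3: the same change on two cores in this assay, a 1.3-fold lower number (0.11 log units; within the scatter) from compound 1 to compound 2 and an at least 3.8-fold lower number (0.58 log units; beyond the scatter) from compound 3 to compound 4, at least 2.9-fold (0.47 log units) apart, beyond the scatter of two such steps.
Compound 3 gives > 50000 nM, which is a limit of the assay and not a number.
The step, an at least 3.8-fold lower number from compound 3 to compound 4 (0.58 log units; beyond the scatter), is therefore bounded on one side only, and two pairs show neither a rule for other cores nor a cause for the gap.

Open, from the compounds shown here alone, is how an amine or a carboxylic acid would compare with the methoxy entering compound 4, at the same place on the ring. Also open, going by these compounds, is whether a methoxy ortho to two methoxy groups would give a similar step on the core of compound 1.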